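Triazolylacetamide series: azole amide swap on compound 3

This account rests on a few compounds, and the source may have more. Where it says the series, first, only, none or still open, it means among the compounds named here.

Measured compounds:
compound 1 `Cc1cc(NC(=O)Cn2cc(-c3ccc(Cl)cc3)nn2)no1` 1910 nM
compound 2 `O=C(Cn1cc(-c2ccccc2Cl)nn1)Nc1nccs1` 60 nM
compound 3 `Cc1csc(NC(=O)Cn2cc(-c3ccccc3Cl)nn2)n1` 1240 nM

For the measured compounds named here, in a functional assay on BMDM cells (Mus musculus, strain C57BL/6) for inhibition, with a stated time of 2 days (on this read-out lower numbers stand for stronger inhibition and higher numbers for weaker inhibition), compound 3 stands second highest of the three numbers; compound 1 sits within the scatter of it, while compound 2 lies well below it, the only measured step being a 21-fold higher number from compound 2 to compound 3 (1.32 log units; beyond the scatter). Compound 4 `Cc1cc(NC(=O)Cn2cc(-c3ccccc3Cl)nn2)no1` differs from compound 3 by 5-methyl-1,2-oxazol-3-yl in place of 4-methyl-1,3-thiazol-2-yl on an amide-type nitrogen. Going by the values given here, no measured step bears directly on this change. Compound 1 carries the same 5-methyl-1,2-oxazol-3-yl group and gives 1910 nM, a number close to that of compound 3, so no step beyond the scatter is expected. Compound 4 is therefore estimated at 1500 nM (range 500 nM to 5000 nM), an expected step of a 1.2-fold higher number from compound 3 to compound 4 (0.08 log units; within the scatter).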

Compound 4, half-maximal inhibitory concentration: > 30000 nM
Compound 4 was reported as a limit (the forecaster's own chance of this, stated with the estimate: 10%); middle value at least 20-fold (1.30 log units) away from the limit.
By their numbers in this assay, from the lowest: compound 2; then compounds 3 and 1 (each within the scatter of the next). At a limit, above all of these: compound 4.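

In this assay, compound 4 is reported only as a limit: the limit of > 30000 nM in this assay, at which 1 of the 4 values shown sits.
On the amide-type nitrogen, 5-methyl-1,2-oxazol-3-yl in place of 4-methyl-1,3-thiazol-2-yl gives an at least 24-fold higher number from compound 3 to compound 4 (1.38 log units; beyond the scatter), and in place of 1,3-thiazol-2-yl it gives an at least 500-fold higher number from compound 2 to compound 4 (2.69 log units; beyond the scatter), so with 2-chlorophenyl held constant this swap is far from neutral. Among the 5-methyl-1,2-oxazol-3-yl amides, 2-chlorophenyl in place of 4-chlorophenyl gives an at least 15-fold higher number from compound 1 to compound 4 (1.19 log units; beyond the scatter), so the aryl substitution also matters with this group.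

Open, on these data alone, is whether the loss follows the ring itself or its methyl. A 1,3-thiazol-2-yl carrying a carboxylic acid or an aminomethyl group would extend the reading at this position.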